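Amide substituent swap on a compound series without measurable cytotoxicity

This account rests on a few compounds, and the source may have more. Where it says the series, first, only, none or still open, it means among the compounds named here.

Compound 1 `CC1=C(C(C)C(=O)NCCN(C)C)c2cc(F)ccc2/C1=C\c1ccc([S+](C)[O-])cc1`: > 50000 nM
Compound 2 `CC1=C(C(C)C(=O)N(C)CCN(C)C)c2cc(F)ccc2/C1=C\c1ccc([S+](C)[O-])cc1`: > 50000 nM

In a functional assay on MDA-MB-231 cells (Homo sapiens) for inhibition, read by CellTiter-Glo, with a stated time of 96 h (a higher number here means that more compound is tolerated, a lower number that less compound is tolerated), compound 1 gives > 50000 nM, which is a limit of the assay. In this assay compound 2 gives > 50000 nM, also a limit. Compound 2 therefore stands only at a limit, with no number of its own. Going by the values given here, the one measured step, a step that the two limits leave unreadable from compound 1 to compound 2, cannot be read because the limit of > 50000 nM in this assay, at which 2 of the 2 values shown sit, covers both ends. Compound 3 `CC1=C(C(C)C(=O)N(CCNC(C)C)C(C)C)c2cc(F)ccc2/C1=C\c1ccc([S+](C)[O-])cc1` differs from compound 2 by isopropyl(2-(isopropylamino)ethyl)amino in place of (2-(dimethylamino)ethyl)(methyl)amino on a carbonyl carbon. With no readable step to lean on, the expected step of a number no higher from compound 2 to compound 3 (the limit leaves the size open) is none beyond the scatter. Compound 3 is expected to give 50000 nM (range 20000 nM to 50000 nM), most likely again reported only as a limit.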

Compound 3, half-maximal cytotoxic concentration: 21300 nM
The estimate for compound 3 lay 2.3-fold (0.37 log units) above the measured number; measured number inside the range.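

Going by these compounds alone, compound 3 gives the first readable change at this carbonyl carbon in this assay: isopropyl(2-(isopropylamino)ethyl)amino brings an at least 2.3-fold lower number from compound 2 to compound 3 (0.37 log units; beyond the scatter) and also an at least 2.3-fold lower number from compound 1 to compound 3 (0.37 log units; beyond the scatter). This shows that the group on this carbonyl carbon can shift the number in this series. On these data alone, the full size of both steps stays open, however: the limit of > 50000 nM in this assay, at which 2 of the 3 values shown sit.

Both isopropyl groups enter together, and the compounds shown do not separate their contributions. As far as these compounds go, how a longer chain between the two nitrogens, or a carboxylic acid in place of the terminal amine, would read in this assay also remains open.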